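Turning one ring stereocentre in a peroxide acid

The source may hold more compounds than are shown below. What is called first, only, known or untested is meant among the compounds shown, and "the series" means these compounds.

Measured so far:
compound 1 `C=C1CCC[C@H]2[C@](C)(CC[C@]3(C)CC[C@@H]([C@@H](C)C(=O)O)OO3)[C@@H](C)CC[C@]12C` gives 1060 nM
compound 2 `C=C1CCCC(C)(C)C1(O)CC/C(C)=C/CC[C@]1(C)CC[C@@H]([C@@H](C)C(=O)OC)OO1` gives > 17500 nM

Both compounds were tested in a functional assay on HCT-116 cells (Homo sapiens) for inhibition; a lower number here means a stronger inhibitor of growth, a higher number a weaker inhibitor of growth. Within the data shown here, compound 1 is the only one of the pair with an actual number, 1060 nM. For compound 2 the assay reports only a limit, > 17500 nM, so no number is known for it. This means compound 1 is the one fixed point from which any expectation has to start (the limit of > 17500 nM in this assay, at which 1 of the 2 values shown sits).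

The unmeasured compound 3 `C=C1CCC[C@H]2[C@](C)(CC[C@]3(C)CC[C@H]([C@@H](C)C(=O)O)OO3)[C@@H](C)CC[C@]12C` is a close relative of compound 1. the two compounds have the same atoms and bonds and differ only in configuration as drawn: 1 of 7 stereo elements differ; a stereocentre at a saturated ring carbon is drawn S in compound 1 and R in compound 3 Nothing else is altered.

Among the measured compounds shown here, no pair of measured compounds that differ in one place is available, so there is no measured step to lean on for this kind of change. A single change of configuration in a ring can leave growth inhibition much as it was or shift it noticeably, and from the two values shown alone no direction can be read. The expected step from compound 1 to compound 3 is a 1.5-fold higher number from compound 1 to compound 3 (0.18 log units; within the scatter), a small weakening that may well lie within the scatter. Compound 3 is therefore estimated at 1600 nM, between 400 nM and 7000 nM.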

Compound 3, concentration for 50% growth inhibition: 1800 nM
Estimate against measurement, compound 3: 1.1-fold (0.05 log units) below; measured number inside the range.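

In this assay, turning this one saturated ring carbon from S to R gives a 1.7-fold higher number from compound 1 to compound 3 (0.23 log units; within the scatter), a step that lies within the usual scatter of repeated measurements. For growth inhibition in these cells, the configuration at this carbon therefore does not separate the two compounds, and this pair provides the first measured step of its kind among the compounds shown. The comparison is a clean one, with only a single difference to consider: the fact that compounds 1 and 3 differ only in the configuration as drawn

Among these compounds, compound 2 gives > 17500 nM, which is a limit of the assay and not a number, and it differs from compound 1 in more than one place, so it offers no step to set beside this one. Going by these compounds, it remains open whether this carbon would matter as little with an amide in place of the carboxylic acid, and whether the other stereocentres in the shared core can also be turned with so small a step.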